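Replacing one aromatic group on a carbonyl carbon

The source may report more compounds than this note shows. Statements on the series, on what has been measured and on what is new or still open speak of the compounds shown alone.

Measured in an in vitro ADME assay on microsomes from liver (Homo sapiens) for metabolic stability; on this read-out higher numbers stand for fast clearance and lower numbers for slow clearance:
- Compound 1 `COc1ccc(C(=O)N2CCC(=CC(=O)N[C@@H]3CCN(Cc4ccc5cc(F)ccc5c4)C3)CC2)cc1`: 252 mL/min/kg
- Compound 2 `COc1ccc(O)c(C(=O)N2CCC(=CC(=O)N[C@@H]3CCN(Cc4ccc5cc(F)ccc5c4)C3)CC2)c1`: 119 mL/min/kg

Compound 2 has the lower of the two numbers in this assay, at 119 mL/min/kg. Compound 3 `O=C(C=C1CCN(C(=O)c2cccc(F)c2)CC1)N[C@@H]1CCN(Cc2ccc3cc(F)ccc3c2)C1` differs from it in one place: 3-fluorophenyl in place of 2-hydroxy-5-methoxyphenyl on a carbonyl carbon. In words, 3-fluorophenyl takes the place of 2-hydroxy-5-methoxyphenyl on a carbonyl carbon.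

Among the compounds with values here, only one measured step concerns this same place: a 2.1-fold lower number from compound 1 to compound 2 (0.33 log units; beyond the scatter). That step is modest but beyond the scatter, and it is the step in which 2-hydroxy-5-methoxyphenyl replaced 4-methoxyphenyl. Within the data shown here, compound 3 loses that group again but does not regain 4-methoxyphenyl, and no measured compound here carries 3-fluorophenyl, so the guide is only a loose one. The closest reference is compound 1 at 252 mL/min/kg, which suggests that a higher number than that of compound 2 is expected, in a step of similar modest size. The estimated change is a 1.6-fold higher number from compound 2 to compound 3 (0.20 log units; within the scatter). For compound 3 the expected value is 190 mL/min/kg, with an estimated range from 90 mL/min/kg to 350 mL/min/kg.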

Compound 3, clearance: 459 mL/min/kg
Compound 3: middle estimate off by 2.4-fold (0.38 log units), on the low side; measured number outside the range, above it.
By their numbers in this assay, from the lowest: compound 2; then compounds 1 and 3 (each within the scatter of the next).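

In this assay, replacing 2-hydroxy-5-methoxyphenyl with 3-fluorophenyl on the carbonyl carbon gives a 3.9-fold higher number from compound 2 to compound 3 (0.59 log units; beyond the scatter), so the lower number of compound 2 now stands out against two other aromatic groups, not just 4-methoxyphenyl. The direct comparison of those two groups gives a 1.8-fold higher number from compound 1 to compound 3 (0.26 log units; within the scatter), which lies within the scatter, so this assay does not tell 3-fluorophenyl and 4-methoxyphenyl apart, and among these three compounds only 2-hydroxy-5-methoxyphenyl gives a clearly different result. No supporting measurement is available to explain why this group differs from the other two.

As far as these compounds go, it remains open whether the lower number depends on the hydroxy group alone or on the hydroxy and methoxy groups together, a question that a compound with 2-hydroxyphenyl on the same carbonyl carbon could help answer. From the compounds shown here alone, it is also open how an aromatic group carrying an amine or a carboxylic acid would behave at this position, and whether any such group could bring the number below that of compound 2.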